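From 4-methylphenyl to 2,4-dimethoxyphenyl on the shared core

This account rests on a few compounds, and the source may have more. Where it says the series, first, only, none or still open, it means among the compounds named here.

In a functional assay on HeLa cells (Homo sapiens) for antiproliferative activity, read by MTT assay, with a stated time of 72 h (on this read-out higher numbers stand for weaker inhibition and lower numbers for stronger inhibition), compound 1 (`COc1cc(C(=O)c2sc3ccccc3c2-c2ccc(C)cc2)cc(OC)c1OC`) gives 3700 nM and compound 2 (`COc1ccccc1-c1c(C(=O)c2cc(OC)c(OC)c(OC)c2)sc2ccccc12`) gives 5000 nM with the two values within the scatter of each other. Compound 3 (`COc1ccc(-c2c(C(=O)c3cc(OC)c(OC)c(OC)c3)sc3ccccc23)c(OC)c1`) carries 2,4-dimethoxyphenyl in place of 4-methylphenyl on an aromatic carbon. Going by the values given here, the one measured step at this place, a 1.4-fold higher number from compound 1 to compound 2 (0.13 log units; within the scatter) for 2-methoxyphenyl in place of 4-methylphenyl, bears on it and stays within the scatter. No step beyond the scatter is therefore expected in this assay here. The expected step is a 1.3-fold higher number from compound 1 to compound 3 (0.11 log units; within the scatter) on this reasoning. Compound 3 is estimated at 4800 nM with a range from 1600 nM to 14000 nM as expected limits.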

Compound 3, half-maximal inhibitory concentration: 3900 nM
The estimate for compound 3 lay 1.2-fold (0.09 log units) above the measured number; the measured number falls inside the stated range.
By their numbers in this assay, from the lowest: compounds 1, 3 and 2 (each within the scatter of the next).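

In this assay the 2,4-dimethoxyphenyl group gives a 1.1-fold higher number from compound 1 to compound 3 (0.02 log units; within the scatter) at this position on the shared core, so two methoxy groups on this aromatic ring are tolerated in place of the methyl group of 4-methylphenyl. Methoxy in place of hydrogen on an aromatic carbon gives a 1.3-fold lower number from compound 2 to compound 3 (0.11 log units; within the scatter) as well, so this single methoxy step also stays within the scatter. No measurement offered here accounts for these results. As far as these compounds go, whether an amine or a carboxylic acid on this aromatic ring would bring a step beyond the scatter remains open. So does the outcome of replacing the ring with a longer chain.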